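This account rests on a few compounds, and the source may have more. Where it says the series, first, only, none or still open, it means among the compounds named here.

Measured compounds in an assay for inhibition of serine/threonine-protein kinase PLK2 (Homo sapiens), read by FRET and Z'-LYTE, with a stated time of 1 h; a higher number here means a weaker inhibitor, a lower number a stronger inhibitor:
- compound 1 `CC[C@@H]1C(=O)N(C)c2cnc(-n3ccc4cc(C(N)=O)ccc43)nc2N1C1CCCC1` gives 28.5 nM
- compound 2 `CC[C@@H]1C(=O)N(C)c2cnc(-n3ccc4cc(F)ccc43)nc2N1C1CCCC1` gives 969 nM
- compound 3 `CC[C@@H]1C(=O)N(C)c2cnc(-n3ccc4cc(C(=O)NCC(C)C)ccc43)nc2N1C1CCCC1` gives 18.6 nM

Compound 3 has the lowest of the three numbers in this assay, but its gap to compound 1 is within the scatter, so the two cannot be ranked against each other; only compound 2 stands clearly apart, with a far higher number.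

Compound 4 `CC[C@@H]1C(=O)N(C)c2cnc(-n3ccc4cc(C(=O)NC5CCCC5)ccc43)nc2N1C1CCCC1` is not yet measured. Relative to compound 3 the change is cyclopentyl in place of isobutyl on an amide-type nitrogen.

Two of the measured steps speak to this. The substituent on the aromatic carbon matters a great deal: a 34-fold higher number from compound 1 to compound 2 (1.53 log units; beyond the scatter) and a 52-fold lower number from compound 2 to compound 3 (1.72 log units; beyond the scatter) show that the carbamoyl group is what separates the low numbers from the high one. What sits on the amide-type nitrogen, by contrast, has so far made little difference: a 1.5-fold lower number from compound 1 to compound 3 (0.19 log units; within the scatter), a step within the scatter. Compound 4 keeps the carbamoyl and only swaps one alkyl group on the amide nitrogen for another, so no step beyond the scatter is expected in this assay, in either direction; the estimated step is a 1.0-fold lower number from compound 3 to compound 4 (0.01 log units; within the scatter).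

The estimate for compound 4 in this assay is 18 nM, with a range from 8 nM to 45 nM.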

Compound 4, half-maximal inhibitory concentration: 7.06 nM
For compound 4 the middle estimate is 2.5-fold (0.41 log units) above the measured one; measured number below the stated range.
By their numbers in this assay, from the lowest: compound 4; then compounds 3 and 1 (each within the scatter of the next); then compound 2.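

The amide-type nitrogen is more sensitive to what it carries than compound 3 alone suggested: in this assay, isobutyl gave only a 1.5-fold lower number from compound 1 to compound 3 (0.19 log units; within the scatter), whereas cyclopentyl gives a 4.0-fold lower number from compound 1 to compound 4 (0.61 log units; beyond the scatter), and replacing isobutyl with cyclopentyl gives a 2.6-fold lower number from compound 3 to compound 4 (0.42 log units; beyond the scatter). The choice of alkyl group therefore shifts the number beyond the scatter, though this modest step remains much smaller than the large step seen on replacing fluoro on the aromatic carbon with cyclopentylcarbamoyl, a 140-fold lower number from compound 2 to compound 4 (2.14 log units; beyond the scatter), and compound 4 now has the lowest number of the four compounds. None of the data shown explains why cyclopentyl gives the lower number.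

Isobutyl and cyclopentyl differ both in carbon count and in the presence of a ring, so the step cannot be assigned to either feature; an open-chain pentyl group would address the first, while cyclobutyl and cyclohexyl would show how far the result depends on ring size. The compounds shown also leave open whether the cyclopentyl ring tolerates a substituent such as a hydroxyl or an amine.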